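Longer Selenium-Bearing Chain Across Two Matched Pairs

The compounds below may be only part of what the source reports. "The series", "measured", "known", "first", "only" and "open" are said of these compounds alone.

Of the compounds shown here, three that share a common core have been tested in a functional assay on MCF7 cells (Homo sapiens) for cytotoxicity, read by MTT assay, with a stated time of 24 h; on this read-out lower numbers stand for stronger inhibition and higher numbers for weaker inhibition. Compound 1 `CC1=C(SCCC(=O)OC(C[Se]c2ccccc2)C(=O)NCCCCCC(=O)OCc2ccccc2)C(=O)c2ccccc2C1=O` carries a long amide-linked chain ending in an ester; in this assay compound 1 gives 10000 nM. Compound 2 `CC1=C(SCCC(=O)OC(CC[Se]c2ccccc2)C(=O)NCCCCCC(=O)OCc2ccccc2)C(=O)c2ccccc2C1=O` differs from compound 1 in a single place: a group of 8 heavy atoms (7 carbon, 1 selenium; one six-membered aromatic ring of carbon only) in place of a group of 7 heavy atoms (6 carbon, 1 selenium; one six-membered aromatic ring of carbon only), on a saturated chain carbon, two bonds along the chain from a carbonyl carbon and an oxygen next to a carbonyl group. In this assay compound 2 gives 19000 nM. That change gave a 1.9-fold higher number from compound 1 to compound 2 (0.28 log units; within the scatter), a step that stays inside the usual scatter of repeated measurements, so the two numbers cannot be told apart with confidence. Compound 3 `CC1=C(SCCC(=O)OC(C[Se]c2ccccc2)C(=O)NC(C)(C)C)C(=O)c2ccccc2C1=O` carries a shorter amide end in place of the long chain; in this assay compound 3 gives 14000 nM. The difference between the core of compound 1 and the core of compound 3 is not broken down here. Compound 4 `CC1=C(SCCC(=O)OC(CC[Se]c2ccccc2)C(=O)NC(C)(C)C)C(=O)c2ccccc2C1=O` has not yet been measured and differs from compound 3 by the same change seen earlier: a group of 8 heavy atoms (7 carbon, 1 selenium; one six-membered aromatic ring of carbon only) in place of a group of 7 heavy atoms (6 carbon, 1 selenium; one six-membered aromatic ring of carbon only), on a saturated chain carbon, two bonds along the chain from a carbonyl carbon and an oxygen next to a carbonyl group. The place of the change is described in identical words for both pairs, so the measured pair is the closest available guide. Among the measured compounds shown here, compound 4 is expected to show a 1.4-fold higher number from compound 3 to compound 4 (0.15 log units; within the scatter), because a 1.9-fold higher number from compound 1 to compound 2 (0.28 log units; within the scatter) was the outcome of the same change and is the only example available. Starting from compound 3 at 14000 nM, in this assay compound 4 is therefore estimated at 20000 nM, with a plausible range from 9000 nM to 45000 nM that allows for the scatter seen in such measurements.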

Compound 4, half-maximal inhibitory concentration: 26000 nM
Compound 4: middle estimate off by 1.3-fold (0.11 log units), on the low side; low and high end bracket the measured number.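

In this assay, the longer selenium-bearing group gave a 1.9-fold higher number from compound 3 to compound 4 (0.27 log units; within the scatter), a step that on its own cannot be told apart from what repeated measurements of one compound would give. Among the compounds shown here, this does not show that the change has a real effect on cytotoxicity: both steps lie within the scatter, so their agreement may mean only that neither step is distinguishable from no change, and two cores are too few to support a rule for the whole series. What the pairs do show is that, so far, the change reads the same whether the amide end is the long ester-bearing chain of compound 1 or the shorter end of compound 3, and the earlier step is therefore a fair guide on these two cores: the same change on two cores in this assay, a 1.9-fold higher number (0.28 log units; within the scatter) from compound 1 to compound 2 and a 1.9-fold higher number (0.27 log units; within the scatter) from compound 3 to compound 4, 1.0-fold (0.01 log units) apart, within the scatter of two such steps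

The compounds shown leave open whether a longer chain carrying the selenium would give a step large enough to stand clear of the scatter, and what sulfur in place of the selenium would do. They also leave open how the same change would behave on a core whose amide end carries an amine or a carboxylic acid, and whether the picture holds in any assay other than this one.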